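The source may report more compounds than this note shows. Statements on the series, on what has been measured and on what is new or still open speak of the compounds shown alone.

Compound 1, `O=C(Oc1ccc2c(c1)C(=O)C=CC2=O)c1ccccc1`, in a functional assay on KB cells (Homo sapiens) for cytotoxicity (on this read-out higher numbers stand for weaker inhibition and lower numbers for stronger inhibition), gives 12100 nM.
Compound 2, `CC(=O)Oc1ccc2c(c1)C(=O)C=CC2=O`, in this assay gives 22100 nM.
Compound 3, `O=C1C=C(Oc2ccco2)C(=O)c2ccccc21`, in this assay gives 53400 nM.

Among these three numbers compound 2 holds the second highest place. Its nearest neighbour is compound 1, whose number is lower by a step that stays within the scatter, a 1.8-fold higher number from compound 1 to compound 2 (0.26 log units; within the scatter); that step is methyl in place of phenyl on a carbonyl carbon. Compound 3 gives the highest number, and the gap from compound 2 to compound 3 lies beyond the scatter.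

Compound 4, `O=C1C=CC(=O)c2cc(Oc3ccco3)ccc21`, has not yet been measured in this assay. It differs from compound 2 in one place: furan-2-yl in place of acetyl on an oxygen on an aromatic ring. For the measured compounds named here, the only measured step, from compound 1 to compound 2, also exchanged the group on that same oxygen and moved the number by less than the scatter, so a change of the ester group alone has so far given no clear shift. Compound 3 carries a (furan-2-yl)oxy group elsewhere on the shared core and shows the highest number, which is a hint rather than a rule. A step from compound 2 to compound 4 of about a 1.3-fold higher number from compound 2 to compound 4 (0.10 log units; within the scatter) is therefore expected, at most a mild rise. For compound 4 in this assay the estimate is 28000 nM, with a likely range from 10000 nM to 75000 nM.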

Compound 4, half-maximal inhibitory concentration: 15800 nM
The estimate for compound 4 lay 1.8-fold (0.25 log units) above the measured number, and the stated range covers the measured number.
By their numbers in this assay, from the lowest: compounds 1, 4 and 2 (each within the scatter of the next); then compound 3.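

In this assay, for the compounds shown here, the step of a 1.4-fold lower number from compound 2 to compound 4 (0.15 log units; within the scatter) is the first on this oxygen to remove the carbonyl group altogether, since the earlier step only changed what the carbonyl carbon carried. Acetyl gives way to furan-2-yl, a five-membered aromatic ring, and the number still stays within the scatter. At this position on the aromatic ring, then, even this larger change of group type gives no clear shift in cytotoxicity. Nothing measured here offers a reason for this.

On these data alone, what remains open is whether any group on this oxygen can move the number beyond the scatter, for example a chain ending in an amine or a carboxylic acid. A free hydroxyl at the same place would also show how much the attached group contributes at all.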